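The compounds below may be only part of what the source reports. "The series", "measured", "known", "first", "only" and "open" are said of these compounds alone.

Among the compounds with values here, in a functional assay on MCF7 cells (Homo sapiens) for antiproliferative activity, read by MTT assay, with a stated time of 72 h (a higher number here means a weaker inhibitor, a lower number a stronger inhibitor), three compounds sharing one core have numbers so far: compound 1 `CCN(CC)CCNC(=O)c1cc(C(CC)(CC)c2ccc(C#CC(O)(CC)CC)c(C)c2)cn1CC` gives 1800 nM, compound 2 `CCn1cc(C(CC)(CC)c2ccc(C#CC(O)(CC)CC)c(C)c2)cc1C(=O)NCC(=O)O` gives 17500 nM and compound 3 `CCn1cc(C(CC)(CC)c2ccc(C#CC(O)(CC)CC)c(C)c2)cc1C(=O)N[C@@H](C(=O)O)C(C)C` gives 18000 nM. Compound 3 therefore sits level with compound 2 (a 1.0-fold higher number from compound 2 to compound 3 (0.01 log units; within the scatter)) and well on the weak side of compound 1 (a 10-fold higher number from compound 1 to compound 3 (1.00 log units; beyond the scatter)).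

Compound 4 `CCn1cc(C(CC)(CC)c2ccc(C#CC(O)(CC)CC)c(C)c2)cc1C(=O)N[C@@H](C)CO` is reached from compound 3 by one change (1-(hydroxymethyl)ethyl in place of 1-carboxy-2-methylpropyl on an amide-type nitrogen), in which 1-(hydroxymethyl)ethyl takes the place of 1-carboxy-2-methylpropyl on an amide-type nitrogen. Within the data shown here, two measured steps bear on this. The isopropyl that also leaves made no difference beyond the scatter (a 1.0-fold higher number from compound 2 to compound 3 (0.01 log units; within the scatter)), so little is expected from its loss. The carboxy matters more, since the step that brought it in was modest but clear (a 9.7-fold higher number from compound 1 to compound 2 (0.99 log units; beyond the scatter)). Compound 4 has no carboxy, but it also lacks the diethylamino of compound 1, so only part of that step is expected to return in this assay. The expected step is a 3.6-fold lower number from compound 3 to compound 4 (0.56 log units; beyond the scatter). The estimate for compound 4 is 5000 nM, within an expected range of 1600 nM to 15000 nM.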

Compound 4, half-maximal inhibitory concentration: 1910 nM
Compound 4: middle estimate off by 2.6-fold (0.42 log units), on the high side; the range from low to high includes it.
By their numbers in this assay, from the lowest: compounds 1 and 4 (each within the scatter of the next); then compounds 2 and 3 (each within the scatter of the next).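

In this assay the step of a 1.1-fold higher number from compound 1 to compound 4 (0.03 log units; within the scatter) lies within the scatter even though the 1-(hydroxymethyl)ethyl group carries no diethylamino, so the amine of compound 1 is not needed for a number at this level. Putting that same group in place of the carboxy-bearing chains gives a 9.4-fold lower number from compound 3 to compound 4 (0.97 log units; beyond the scatter) and also a 9.2-fold lower number from compound 2 to compound 4 (0.96 log units; beyond the scatter) in this assay. Across these four compounds, the weak numbers therefore go with the two carboxy-bearing chains on the amide-type nitrogen, not with the absence of the diethylamino.

As far as these compounds go, whether the hydroxyl of compound 4 contributes at all remains open, as does how a plain propyl chain or a methyl ester in place of the carboxy would read at this nitrogen. Nothing available here explains why the carboxy-bearing chains give the higher numbers.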